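Trimming the pyrazole on the weakest of three binders

The source may hold more compounds than are shown below. What is called first, only, known or untested is meant among the compounds shown, and "the series" means these compounds.

Of the compounds shown here, three have so far been measured in an assay on isolated protein for binding affinity to Leucine-rich repeat serine/threonine-protein kinase 2 variant G2019S (Homo sapiens), read by TR-FRET and LanthaScreen, with a stated time of 2 h; on this read-out higher numbers stand for weaker inhibition and lower numbers for stronger inhibition. Compound 1 `Cc1c(Nc2nc(N)c3c(C#N)c(N4CCC[C@H]4C)n(C)c3n2)cnn1C` gives 3 nM, compound 2 `C[C@@H]1CCCN1c1c(C#N)c2c(N)nc(Nc3cn[nH]c3)nc2n1C` gives 0.4 nM, and compound 3 `Cc1cn(C)nc1Nc1cc2c(c(N)n1)c(C#N)c(N1CCC[C@H]1C)n2C` gives 75 nM, the highest of the three numbers and therefore the weakest inhibitor shown. Compound 4 `C[C@@H]1CCCN1c1c(C#N)c2c(N)nc(Nc3cnn(C)c3)cc2n1C` has not yet been measured. It differs from compound 3 in a single place: 1-methyl-1H-pyrazol-4-yl in place of 1,4-dimethyl-1H-pyrazol-3-yl on a nitrogen on an aromatic ring.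

Going by the values given here, only one measured step alters the pyrazole alone: a 7.5-fold lower number from compound 1 to compound 2 (0.88 log units; beyond the scatter). That step kept the core of compound 1 and swapped a methylated pyrazole for a bare one; compound 3 and compound 4 share a different core, so the lesson carries over only loosely. Compound 1 and compound 3, which differ in both core and pyrazole, show a wide gap in the same direction. A moderate fall in the number is therefore expected for compound 4, a 7.5-fold lower number from compound 3 to compound 4 (0.88 log units; beyond the scatter). Compound 4 is estimated at 10 nM, within a range from 2.5 nM to 40 nM.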

Compound 4, inhibition constant: 794 nM
Estimate against measurement, compound 4: 79-fold (1.90 log units) below; the whole stated range lies below it.
By their numbers in this assay, from the lowest: compound 2; then compound 1; then compound 3; then compound 4.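

Swapping 1,4-dimethyl-1H-pyrazol-3-yl for 1-methyl-1H-pyrazol-4-yl on a nitrogen on an aromatic ring in this assay gives an 11-fold higher number from compound 3 to compound 4 (1.02 log units; beyond the scatter) and thus weaker inhibition, and the group names show that a methyl group and the ring's point of attachment change together in this single step. Going by these compounds alone, the only earlier pyrazole step, a 7.5-fold lower number from compound 1 to compound 2 (0.88 log units; beyond the scatter) on the core of compound 1, ran toward stronger inhibition, so changes to the pyrazole at this nitrogen do not all move the number the same way. Nothing shown here explains why the number rose.

Still open, from the compounds shown here alone, is whether the lost methyl group or the moved attachment point matters more, which a 1-methyl-1H-pyrazol-3-yl group on the core shared by compound 3 and compound 4 could help separate. Also open, going by these compounds, is how a bare 1H-pyrazol-4-yl group or an ethyl chain on the pyrazole nitrogen would read on that core.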